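Swapping the amide for a methanesulfonamide on the distal ring

The source may hold more compounds than are shown below. What is called first, only, known or untested is meant among the compounds shown, and "the series" means these compounds.

Three compounds share one core and differ only in a group on the outer ring of the biphenyl. Compound 1 `O=C(O)CC/C=C\CO[C@H]1C(OCc2ccc(-c3ccccc3)cc2)CC[C@@H]1N1CCCCCC1` carries no such group; in a functional assay on blood for antagonist activity at thromboxane A2 receptor (Homo sapiens) (a higher number here means weaker binding, a lower number tighter binding), compound 1 gives 12.6 nM. Compound 2 `NC(=O)Cc1ccccc1-c1ccc(COC2CC[C@H](N3CCCCCC3)[C@H]2OC/C=C\CCC(=O)O)cc1` bears a carbamoylmethyl group, and compound 2 gives 7.94 nM. Compound 3 `NC(=O)c1ccccc1-c1ccc(COC2CC[C@H](N3CCCCCC3)[C@H]2OC/C=C\CCC(=O)O)cc1` bears a carbamoyl group, and compound 3 gives 15.9 nM. Every step among these three stays within the scatter: a 1.6-fold lower number from compound 1 to compound 2 (0.20 log units; within the scatter), a 1.3-fold higher number from compound 1 to compound 3 (0.10 log units; within the scatter) and a 2.0-fold higher number from compound 2 to compound 3 (0.30 log units; within the scatter). Compound 3 therefore stands together with compound 1 and compound 2, none set apart from the others.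

Compound 4 `CS(=O)(=O)Nc1cccc(-c2ccc(COC3CC[C@H](N4CCCCCC4)[C@H]3OC/C=C\CCC(=O)O)cc2)c1` takes this further: 3-(methanesulfonamido)phenyl in place of 2-carbamoylphenyl on an aromatic carbon. Within the data shown here, no measured step involves a methanesulfonamide, so the only guidance is that the three changes already made at this ring, a hydrogen, a carbamoyl and a carbamoylmethyl group, all left this assay within the scatter. On that basis the expected step is small, a 1.3-fold lower number from compound 3 to compound 4 (0.12 log units; within the scatter), with no direction beyond the scatter. Compound 4 is estimated at 12 nM, with a range from 4 nM to 40 nM.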

Compound 4, dissociation constant: 12.6 nM
Compound 4: the middle estimate sits 1.1-fold (0.02 log units) below what was measured, and the stated range covers the measured number.
By their numbers in this assay, from the lowest: compounds 2, 1, 4 and 3 (each within the scatter of the next).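

The step of a 1.3-fold lower number from compound 3 to compound 4 (0.10 log units; within the scatter) shows that this outer ring accepts a sulfur-bearing group: 3-(methanesulfonamido)phenyl, with 11 heavy atoms, replaces 2-carbamoylphenyl, with 9, and the number stays within the scatter. The other two comparisons agree, with a 1.6-fold higher number from compound 2 to compound 4 (0.20 log units; within the scatter) against the carbamoylmethyl group and no change at the digits printed from compound 1 to compound 4 (within the scatter) when methanesulfonamido replaces hydrogen, so in this assay all four outer-ring patterns shown remain indistinguishable. Nothing available here explains why these changes leave the number within the scatter.

The step from compound 3 to compound 4 changes both the group and the ring location given in its name, so the compounds shown cannot separate the contribution of either change. From the compounds shown here alone, it also remains open whether an amine, a carboxylic acid or a longer chain on this ring would keep the number within the scatter or finally move it beyond.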